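This account rests on a few compounds, and the source may have more. Where it says the series, first, only, none or still open, it means among the compounds named here.

Compound 2, with the structure `CCN(Cc1ccncc1)c1ccc(C(=O)N2CCc3ccc(OS(N)(=O)=O)cc3C2)cc1`, stands highest of the two numbers measured in an assay on HEK293 cells for inhibition of Steryl-sulfatase (Homo sapiens), tested at 0.1 uM (on this read-out lower numbers stand for a weaker effect and higher numbers for a stronger effect at the one concentration tested), where compound 2 gives 47%. Its neighbour, compound 1, with the structure `CCN(Cc1cccnc1)c1ccc(C(=O)N2CCc3ccc(OS(N)(=O)=O)cc3C2)cc1`, gives 35.7% in this assay. For the measured compounds named here, the one measured step, a number 11.3 percentage points higher from compound 1 to compound 2 (beyond the scatter), moved the ring nitrogen within a pyridine ring.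

Compound 3, with the structure `CCN(Cc1ccc(F)cc1)c1ccc(C(=O)N2CCc3ccc(OS(N)(=O)=O)cc3C2)cc1`, differs from compound 2 by 4-fluorophenyl in place of pyridin-4-yl on a saturated chain carbon bound to a nitrogen on an aromatic ring. Going by the values given here, no measured step covers this change: the only step available concerns where the ring nitrogen sits, not its exchange for a fluorine-bearing carbon ring, so it bears only loosely on compound 3. The expectation is therefore a modest step, a number 7 percentage points lower from compound 2 to compound 3 (within the scatter), with little confidence in its direction. For compound 3 the estimated value in this assay is 40%, expected to lie between 20% and 60%.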

Compound 3, a percentage reported as inhibition, at one concentration (the size of the read-out at that concentration, not a potency): 69.1%
Compound 3: middle estimate off by 29.1 percentage points, on the low side, and the stated range ends below it.
By their numbers in this assay, from the lowest: compound 1; then compound 2; then compound 3.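

In this assay, 4-fluorophenyl in place of pyridin-4-yl gives a number 22.1 percentage points higher from compound 2 to compound 3 (beyond the scatter), and 4-fluorophenyl in place of pyridin-3-yl gives a number 33.4 percentage points higher from compound 1 to compound 3 (beyond the scatter). The earlier step showed only that this position responds to where the ring nitrogen sits; these steps show that a ring of carbon only, carrying fluorine, can stand above both pyridine rings tested here. No measured information is available to explain this rise.

From the compounds shown here alone, whether the gain belongs to the fluorine or to the all-carbon ring remains open, and a plain phenyl ring with no fluorine would help separate the two. Going by these compounds, it also remains open whether a chlorine in place of the fluorine, or a longer chain in place of the ethyl group on the same nitrogen, would raise or lower the number.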